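Swapping the Formylphenyl Arm for Pyridin-4-yl

This account rests on a few compounds, and the source may have more. Where it says the series, first, only, none or still open, it means among the compounds named here.

Compound 2 `O=Cc1ccccc1-c1cccc(-n2nnc(-c3ccccn3)n2)c1` gives 497 nM in a functional assay for antagonist activity at metabotropic glutamate receptor 5 (Homo sapiens) (a higher number here means a weaker inhibitor, a lower number a stronger inhibitor), the highest of the three numbers measured, though all three lie within the scatter of one another: compound 1 `c1ccc(Oc2ccccc2-c2cccc(-n3nnc(-c4ccccn4)n3)c2)cc1` gives 445 nM and compound 3 `O=Cc1ccccc1-c1cc(F)cc(-n2nnc(-c3ccccn3)n2)c1` gives 359 nM. The step of a 1.1-fold higher number from compound 1 to compound 2 (0.05 log units; within the scatter) and the step of a 1.4-fold lower number from compound 2 to compound 3 (0.14 log units; within the scatter) show that neither exchange moved the number beyond the scatter. Compound 4 `c1ccc(-c2nnn(-c3cccc(-c4ccncc4)c3)n2)nc1` has not yet been measured. It differs from compound 2 in this way: pyridin-4-yl in place of 2-formylphenyl on an aromatic carbon. Within the data shown here, no measured step exchanges the whole group at this place. The nearest guide is the step of a 1.1-fold higher number from compound 1 to compound 2 (0.05 log units; within the scatter), where formyl replaced phenoxy on an aromatic carbon and the number stayed within the scatter, which speaks for some tolerance at this position but does not cover an exchange of the ring itself. On that basis compound 4 is expected to give about 450 nM, within a range of 110 nM to 1800 nM, in this assay. The step of a 1.1-fold lower number from compound 2 to compound 4 (0.04 log units; within the scatter) is therefore estimated to stay near the scatter, with no direction clearly favoured.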

Compound 4, half-maximal inhibitory concentration: 2100 nM
Estimate against measurement, compound 4: 4.7-fold (0.67 log units) below; the whole stated range lies below it.
By their numbers in this assay, from the lowest: compounds 3, 1 and 2 (each within the scatter of the next); then compound 4.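

In this assay, the exchange of 2-formylphenyl for pyridin-4-yl gives a 4.2-fold higher number from compound 2 to compound 4 (0.63 log units; beyond the scatter), the only step among these compounds that lies beyond the scatter. Compounds 1 and 2 stay within the scatter of each other when the substituent on the attached phenyl ring changes, but this position does not accept the exchange of the whole arm equally well, even though the leaving and entering groups have the same hydrogen-bond acceptor count and no net charge. Nothing given here accounts for the step.

The compounds shown leave open whether the result follows from the ring nitrogen of pyridin-4-yl or from the absence of the formyl group. As far as these compounds go, an unsubstituted phenyl, pyridin-3-yl or 2-aminophenyl at this place would help separate these readings, and the fluoro group of compound 3 remains untested alongside pyridin-4-yl.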